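This account rests on a few compounds, and the source may have more. Where it says the series, first, only, none or still open, it means among the compounds named here.

Compound 1 `COc1cccc(/C=C2\CCC/C(=C\c3ccc(Cl)cc3)C2=O)c1OC` gives > 20000 nM in a functional assay on A549 cells (Homo sapiens) for cytotoxicity, read by MTT assay, with a stated time of 72 h (a higher number here means a weaker inhibitor, a lower number a stronger inhibitor), which is a limit of the assay and not a number.
Compound 2 `COc1ccc(/C=C2\CCC/C(=C\c3cccc(OC)c3OC)C2=O)cc1` gives > 20000 nM in this assay, again a limit rather than a number.
Compound 3 `COc1cccc(/C=C2\CCC/C(=C\c3ccc(O)c(Cl)c3)C2=O)c1OC` gives > 20000 nM in this assay, again a limit rather than a number.

The three compounds share a core and differ only in the groups on its two outer rings. Compound 1 and compound 3 are distinguished by 3-chloro-4-hydroxyphenyl in place of 4-chlorophenyl on a double-bonded chain carbon bound to a double-bonded ring carbon. Compound 1 and compound 2 are distinguished by methoxy in place of chloro on an aromatic carbon, and the step that this change made, a step that the two limits leave unreadable from compound 1 to compound 2, cannot be read because of the limit of > 20000 nM in this assay, at which 3 of the 3 values shown sit. The same holds for a step that the two limits leave unreadable from compound 1 to compound 3 and a step that the two limits leave unreadable from compound 2 to compound 3.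

Compound 4 `COc1cc(/C=C2\CCC/C(=C\c3cccc(OC)c3OC)C2=O)ccc1O` has not yet been measured. It differs from compound 3 by methoxy in place of chloro on an aromatic carbon. Among the compounds with values here, this is the same kind of change as the one from compound 1 to compound 2, but the surroundings differ: in compound 1 the chloro sits para to a large group, whereas in compound 3 it sits ortho to a hydroxy group and meta to a large group.

Since the change from compound 1 to compound 2 left both values at the limit, the step that the limit leaves unreadable from compound 3 to compound 4 is expected to be small. Compound 4 is therefore estimated at 25000 nM, with a likely range from 8000 nM to 80000 nM, and it is expected most likely to appear only as a limit again.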

Compound 4, half-maximal inhibitory concentration: > 20000 nM
Compound 4: no number, only a limit; the forecaster's own chance of this, stated with the estimate: 75%; the middle value is on the limit's open side.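

Within the data shown here, compound 4 is a limit and not a number in this assay too, so no step linking compound 1, compound 2, compound 3 and compound 4 can be read, because all four results stop at the same point: the limit of > 20000 nM in this assay, at which 4 of the 4 values shown sit.

The compounds shown leave open how strong any of these four compounds really is, and whether any change on the outer rings alters the result in this assay at all.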